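Notes on the step from compound 3 to compound 4

A few compounds are considered here, and "the series" means these few. Any claim that something is new, unique, unknown or untested is made for them only; others in the source may bear on it.

In a functional assay on Shh Light II cells (Mus musculus) for inhibition, read by a luciferase reporter (a higher number here means a weaker inhibitor, a lower number a stronger inhibitor), compound 3 (`O=C(OC1CCCCC1)N1CCC(c2nc(-c3ccc4ccccc4n3)no2)CC1`) gives 580 nM. Compound 2 (`O=C(CC1CCCCCC1)N1CCC(c2nc(-c3ccc4ccccc4n3)no2)CC1`) gives 840 nM, which is within the scatter of compound 3. Compound 1 (`O=C(NC1CCCCC1)N1CCN(c2nc(-c3ccc4ccccc4n3)no2)CC1`) gives 53 nM, a lower number than compound 3 by more than the scatter.

The next compound is compound 4 (`COc1ccccc1NC(=O)N1CCC(c2nc(-c3ccc4ccccc4n3)no2)CC1`), with this change from compound 3: (2-methoxyphenyl)amino in place of cyclohexyloxy on a carbonyl carbon. Here (2-methoxyphenyl)amino stands in place of cyclohexyloxy on a carbonyl carbon.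

Within the data shown here, one measured step bears directly on this position: a 1.4-fold lower number from compound 2 to compound 3 (0.16 log units; within the scatter). That step also exchanges the group on the carbonyl carbon, and it stays within the scatter. It replaces one non-aromatic ring group with another, however, so it says little about an aromatic group entering. Compound 1, at 53 nM, also has a nitrogen on its carbonyl carbon, but its core differs too, so its value is only a loose hint. Among the measured compounds shown here, no measured pair isolates the change.

A modest move toward a lower number is therefore expected in this assay, with wide uncertainty. The expected step is a 1.9-fold lower number from compound 3 to compound 4 (0.29 log units; within the scatter). Compound 4 is estimated at 300 nM, with an expected range from 80 nM to 1000 nM.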

Compound 4, half-maximal inhibitory concentration: 410 nM
Compound 4: the middle estimate sits 1.4-fold (0.14 log units) below what was measured; low and high end bracket the measured number.
By their numbers in this assay, from the lowest: compound 1; then compounds 4, 3 and 2 (each within the scatter of the next, the first and the last beyond it).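

Across three quite different groups on the carbonyl carbon of the shared core, this assay shows a narrow range: (2-methoxyphenyl)amino is the first aromatic group here and the first on this core to add a hydrogen-bond donor, and it gives a 1.4-fold lower number from compound 3 to compound 4 (0.15 log units; within the scatter). Against cycloheptylmethyl, the same group gives a 2.0-fold lower number from compound 2 to compound 4 (0.31 log units; beyond the scatter), the only step on this core that passes the scatter, and a modest one, so this position accepts an aromatic amino group without a large change in either direction. No measurement at hand accounts for these small differences.

The compounds shown leave open whether the methoxy group or the amino nitrogen carries any of this small gain, a question that unsubstituted phenylamino or a benzyl group on the same carbonyl carbon would address. Among these compounds, they also leave open whether the much lower number of compound 1 belongs to its core or to the group on its carbonyl carbon, as no compound here pairs that core with any other group, or that group with the shared core.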